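Trifluoromethyl for chloro on the anilide of compound 3

The compounds below may be only part of what the source reports. "The series", "measured", "known", "first", "only" and "open" are said of these compounds alone.

Compound 1, `Cc1cccnc1NC(=O)c1cc(F)cc(C#N)c1`, is measured in an in vitro functional assay on HEK293-A cells for antagonist activity at metabotropic glutamate receptor 5 (Rattus norvegicus), read by calcium flux (on this read-out higher numbers stand for weaker inhibition and lower numbers for stronger inhibition), only as a limit, > 30000 nM, and that limit is the limit of > 30000 nM in this assay, at which 1 of the 3 values shown sits. Compound 2, `N#Cc1cc(F)cc(C(=O)Nc2cccc(F)c2)c1`, gives 2160 nM in this assay, and compound 3, `N#Cc1cc(F)cc(C(=O)Nc2cccc(Cl)c2)c1`, gives 45 nM. Within the data shown here, the one step that changes the substituent on the anilide ring is a 48-fold lower number from compound 2 to compound 3 (1.68 log units; beyond the scatter). Among the two numbers, compound 3 holds the lowest, the gap to its nearest neighbour being a 48-fold lower number from compound 2 to compound 3 (1.68 log units; beyond the scatter).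

Compound 4, `N#Cc1cc(F)cc(C(=O)Nc2cccc(C(F)(F)F)c2)c1`, differs from compound 3 by trifluoromethyl in place of chloro on an aromatic carbon. Among the measured compounds shown here, the only measured step at this position, from fluoro to chloro, was large and ran towards stronger inhibition; no step from chloro onward has been measured, so the size of the next step is open. The expectation for compound 4 is therefore a number close to that of compound 3, with any change likely within the scatter, which means a step of no change at the digits printed from compound 3 to compound 4 (within the scatter). Compound 4 is thus estimated at 45 nM, between 12 nM and 180 nM.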

Compound 4, half-maximal inhibitory concentration: 543 nM
Compound 4: the middle estimate sits 12-fold (1.08 log units) below what was measured, and the stated range ends below it.
By their numbers in this assay, from the lowest: compound 3; then compound 4; then compound 2. At a limit, above all of these: compound 1.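

In this assay, among these compounds, the earlier compounds showed this position moving in one direction only, and trifluoromethyl reverses that movement (a 12-fold higher number from compound 3 to compound 4 (1.08 log units; beyond the scatter)). It still keeps part of the gain over fluoro (a 4.0-fold lower number from compound 2 to compound 4 (0.60 log units; beyond the scatter)), so among these three groups chloro gives the lowest number and trifluoromethyl falls in the middle, showing that the position tells these groups apart sharply. Nothing at hand explains why chloro and trifluoromethyl differ so much here.

Where a methyl group, a methoxy group or an amine in the same place would fall relative to chloro remains open. On these data alone, it is also open whether chloro would keep its lead over trifluoromethyl if the core of compound 3 were changed elsewhere.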